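A few compounds are considered here, and "the series" means these few. Any claim that something is new, unique, unknown or untested is made for them only; others in the source may bear on it.

Measured compounds:
Compound 1, `COc1ccc(C(=O)/C=C/c2cc(OC)c(OC)c(OC)c2)c2c1C=CC(C)(C)O2`: 7650 nM in a functional assay on HCT-116 cells (Homo sapiens) for antiproliferative activity, read by MTT assay, with a stated time of 24 h; a lower number here means a stronger inhibitor, a higher number a weaker inhibitor.
Compound 2, `COc1ccc(C(=O)/C=C/c2ccc(N3CCCC3)cc2)c2c1C=CC(C)(C)O2`: 8590 nM in this assay.
Compound 3, `COc1ccc(C(=O)/C=C/c2cccc(C(F)(F)F)c2)c2c1C=CC(C)(C)O2`: 9710 nM in this assay.

Compound 2 stands second highest of the three numbers in this assay; its nearest neighbour is compound 1 and its furthest is compound 3, and both gaps lie within the usual scatter, so no order among the three can be read from these values. The shared core is kept throughout, and the three differently substituted aromatic rings give numbers that cannot be told apart.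

Compound 4, `COc1ccc(C(=O)/C=C/c2ccc(Cl)cc2)c2c1C=CC(C)(C)O2`, has not yet been measured in this assay. It differs from compound 2 in one place:
chloro in place of pyrrolidin-1-yl on an aromatic carbon

For the measured compounds named here, no step between measured compounds is available, so there is no precedent for a change of this kind. Since the three measured compounds sit together whatever group the ring carries, the expected step is small, in no direction beyond the scatter: a 1.0-fold higher number from compound 2 to compound 4 (0.02 log units; within the scatter). Compound 4 is estimated at 9000 nM in this assay, with a range from 4500 nM to 18000 nM.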

Compound 4, half-maximal inhibitory concentration: > 10000 nM
Compound 4: a limit, no number; the forecaster's own chance of this, stated with the estimate: 10%; middle value at least 1.1-fold (0.04 log units) from the limit.
By their numbers in this assay, from the lowest: compounds 1, 2 and 3 (each within the scatter of the next). At a limit, above all of these: compound 4.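

In this assay, for the compounds shown here, chloro in place of pyrrolidin-1-yl on an aromatic carbon, para to a large group, gives an at least 1.1-fold higher number from compound 2 to compound 4 (0.06 log units; that floor lies within the scatter), the only one-place step so far, and it shows that removing the five-membered ring at this position brings no gain. Compound 4 gives > 10000 nM, which is a limit of the assay and not a number. The step therefore has a floor but no size, and that floor does not separate this change from no change, because compound 4 sits at the limit: the limit of > 10000 nM in this assay, at which 1 of the 4 values shown sits.

From the compounds shown here alone, how far the true number for compound 4 lies from that limit remains open, so this position may matter a great deal or hardly at all. Also open, going by these compounds, is how an open-chain amine such as dimethylamino, or a carboxylic acid, on the same aromatic carbon would read in this assay, and whether either would move the number beyond the scatter from compound 2.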